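Pyrrolidin-1-yl in Place of Dimethylamino: A Repeated Change

A few compounds are considered here, and "the series" means these few. Any claim that something is new, unique, unknown or untested is made for them only; others in the source may bear on it.

Three compounds have been measured in an assay on cells for inhibition of Voltage-dependent T-type calcium channel subunit alpha-1H (Homo sapiens), read by patch clamp, tested at 10 uM; on this read-out higher numbers stand for more inhibition at the one concentration tested (going by the name of the read-out) and lower numbers for less inhibition:
compound 1 `O=C(CC1c2ccccc2N=C(SCCCCCN2CCCC2)N1c1ccc(-c2ccc(F)cc2)cc1)NCc1ccc(F)cc1` gives 76.6%;
compound 2 `CN(C)CCCCCSC1=Nc2ccccc2C(CC(=O)NCc2ccccc2)N1c1ccccc1` gives 51.8%;
compound 3 `CN(C)CCCCCSC1=Nc2ccccc2C(CC(=O)NCc2ccc(F)cc2)N1c1ccc(-c2ccc(F)cc2)cc1` gives 84.8%.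

Compound 2 stands lowest of the three; the gap to compound 1 and the larger gap to compound 3 both lie beyond the scatter. How the core of compound 2 differs from that of compound 3 is not broken down here.

Compounds 3 and 1 differ in one place only: pyrrolidin-1-yl in place of dimethylamino on a saturated chain carbon, five bonds along the chain from a sulfur. In this assay that change produced a number 8.2 percentage points lower from compound 3 to compound 1 (within the scatter).

Compound 4 `O=C(CC1c2ccccc2N=C(SCCCCCN2CCCC2)N1c1ccccc1)NCc1ccccc1` is related to compound 2 by the same change: pyrrolidin-1-yl in place of dimethylamino on a saturated chain carbon, five bonds along the chain from a sulfur. For the measured compounds named here, because the only measured example of this change, a number 8.2 percentage points lower from compound 3 to compound 1 (within the scatter), stayed within the scatter, the step for compound 4 is expected to be small, about a number 4.8 percentage points lower from compound 2 to compound 4 (within the scatter). For compound 4, this assay is therefore estimated to give about 47%, with the likely range running from 30% to 64%.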

Compound 4, a percentage reported as inhibition, at one concentration (the size of the read-out at that concentration, not a potency): 61.6%
Beside the measured number, compound 4's estimate is 14.6 percentage points below it; the range from low to high includes it.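

In this assay, putting pyrrolidin-1-yl in place of dimethylamino gave a number 9.8 percentage points higher from compound 2 to compound 4 (within the scatter), and the same change on the other core did not give a matching result: the same change on two cores in this assay, a number 8.2 percentage points lower (within the scatter) from compound 3 to compound 1 and a number 9.8 percentage points higher (within the scatter) from compound 2 to compound 4, 18 percentage points apart, beyond the scatter of two such steps. The size and direction of this step therefore cannot simply be copied from one of these cores to the other. Each step taken alone lies within the scatter, so neither pair by itself shows that pyrrolidin-1-yl raises or lowers inhibition, and the comparison does not reveal which difference between the cores lies behind the gap.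

The compounds shown leave open how a piperidine or a morpholine in place of pyrrolidin-1-yl, or a longer chain leading to the sulfur, would behave on each core. For the compounds shown here, only two cores carry this change here, so it also remains open which part of the core decides the step, and whether a third core would follow either pair.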